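This account rests on a few compounds, and the source may have more. Where it says the series, first, only, none or still open, it means among the compounds named here.

Measured so far:
- compound 1, `Cn1c(=O)[nH]c2c(cnn2-c2ccccc2[N+](=O)[O-])c1=N`: 5%
- compound 2, `CCCn1c(=O)[nH]c2c(cnn2-c2cccc(Cl)c2)c1=N`: 68%
- compound 3, `Cn1c(=O)[nH]c2c(cnn2-c2cccc([N+](=O)[O-])c2)c1=N`: 2%

All three share one core and differ only in the group hanging from the six-membered aromatic ring of carbon only, and in one case in the short chain on the core. In an assay on membranes from brain for binding affinity to adenosine receptor A1 (Rattus norvegicus), read by radioligand binding, tested at 20 uM (a higher number here means more inhibition at the concentration tested (going by the name of the read-out), a lower number less inhibition), compound 3 gives 2%, the lowest of the three numbers. Compound 1 sits within the scatter of it, so the two cannot be told apart, while compound 2 stands far above both, beyond the scatter.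

Compound 4, `Cn1c(=O)[nH]c2c(cnn2-c2cccc(Br)c2)c1=N`, has not yet been measured. It comes from compound 3 by a single change: bromo in place of nitro on an aromatic carbon. A nitro group, with its two oxygen acceptors, gives way to a single bromine atom.

Among the measured compounds shown here, no directly comparable step is at hand. Compound 2 also carries a halogen on that ring and gives 68%, but it also has a propyl rather than a methyl chain, so the two differences cannot be separated. An increase in this assay is expected, of the size a number 28 percentage points higher from compound 3 to compound 4 (beyond the scatter), with wide uncertainty. Compound 4 is estimated at 30%, in the range from 5% to 65%.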

Compound 4, a percentage reported as inhibition, at one concentration (the size of the read-out at that concentration, not a potency): 40%
Compound 4: the middle estimate sits 10 percentage points below what was measured; low and high end bracket the measured number.
By their numbers in this assay, from the lowest: compounds 3 and 1 (each within the scatter of the next); then compound 4; then compound 2.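

On the shared core with its methyl chain, the ring position carrying nitro in compound 3 is not closed to binding: in this assay bromo in place of nitro gives a number 38 percentage points higher from compound 3 to compound 4 (beyond the scatter) and counts as a large change. The earlier compounds shown here differed in ways that could not be pulled apart, whereas this pair shows that the group on this one aromatic carbon can, by itself, move the number beyond the scatter, with the chain on the core left as it was. No measurement at hand explains the step, in which a nitro group with its acceptors gives way to a single bromine atom.

From the compounds shown here alone, whether bromo is special or other groups on this carbon, such as chloro, methoxy or an amine, would do as well or better remains open. Going by these compounds, compound 2 and compound 4 differ in two places, so the shares of the propyl chain and of chloro in place of bromo in the gap between their numbers also remain open, and a propyl chain paired with bromo would be one way to separate them.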